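Weakly active coumarin-type series: isopropyl extension at the ether

A few compounds are considered here, and "the series" means these few. Any claim that something is new, unique, unknown or untested is made for them only; others in the source may bear on it.

Measured compounds:
Compound 1 `COc1ccc(Br)c(CSc2ccc3c(C)cc(=O)oc3c2)c1`: > 25500 nM, a limit of the assay.
Compound 2 `CCc1cc(=O)c2ccc(OC)c(CBr)c2o1`: > 33600 nM, a limit of the assay.
Compound 3 `COc1ccc2c(=O)cc(C(C)Br)oc2c1CBr`: > 26500 nM, a limit of the assay.

In a functional assay on DU-145 cells (Homo sapiens) for antiproliferative activity, read by sulforhodamine B assay, with a stated time of 72 h (a higher number here means a weaker inhibitor of growth, a lower number a stronger inhibitor of growth), none of the three compounds gives a number; each value is a limit. Compound 3 stands at the limit of > 26500 nM in this assay, at which 1 of the 3 values shown sits. Going by the values given here, the one step between measured compounds, a step that the two limits leave unreadable from compound 2 to compound 3, is therefore not readable in size or direction, and the limit of > 25500 nM in this assay, at which 1 of the 3 values shown sits, and the limit of > 33600 nM in this assay, at which 1 of the 3 values shown sits, add nothing on the effect of any structural change.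

Compound 4 `CC(C)COc1ccc2c(=O)cc(C(C)Br)oc2c1CBr` differs from compound 3 by isopropyl in place of hydrogen on a saturated chain carbon bound to an oxygen on an aromatic ring. Among the compounds with values here, no measured step bears on this change. With all three measured compounds at limits, the expectation is that compound 4 again falls at or near the limit in this assay, with no step beyond the scatter expected in either direction. Compound 4 is expected at 30000 nM, with a range from 8000 nM to 100000 nM. The expected step is a step that the limit leaves unreadable from compound 3 to compound 4, and most likely the assay reports only a limit.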

Compound 4, concentration for 50% growth inhibition: 10500 nM
Beside the measured number, compound 4's estimate is 2.9-fold (0.46 log units) above it; low and high end bracket the measured number.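

Going by these compounds alone, replacing hydrogen with isopropyl on the saturated chain carbon bound to an oxygen on an aromatic ring, which turns methoxy into isobutoxy, gives the first readable step in this assay: an at least 2.5-fold lower number from compound 3 to compound 4 (0.40 log units; beyond the scatter). Compound 3 remains a limit of the assay: the limit of > 26500 nM in this assay, at which 1 of the 4 values shown sits. The step is therefore a minimum, and compound 4, at 10500 nM, holds the only number among the compounds shown, so this position is one where a change can move the read-out.

From the compounds shown here alone, whether an ethyl group, a longer chain or a terminal amine at this position would give a similar or larger step remains open. This single pair also cannot show whether the same change would lower the number on the core of compound 2, or why the number falls.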